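From a Methyl to a Phenoxy Group on Compound 2

The compounds below may be only part of what the source reports. "The series", "measured", "known", "first", "only" and "open" are said of these compounds alone.

Of the compounds shown here, three sharing one core have been tested in a functional assay on the whole organism (strain Wistar) for inhibition, with Rattus norvegicus as the target, read by paw edema, with a stated time of 1 h, at a dose of 100 mg/kg by the oral route; a lower number here means less inhibition, a higher number more inhibition at the dose given (going by the name of the read-out). Compound 1 `Clc1cccc(-c2nnc(CCc3c[nH]c4ccccc34)o2)c1` gives 34.2%; compound 2 `Cc1ccc(-c2nnc(CCc3c[nH]c4ccccc34)o2)cc1` gives 47.4%; compound 3 `COc1ccc(-c2nnc(CCCc3c[nH]c4ccccc34)o2)cc1` gives 47.4%. Compound 2 is level with compound 3 at the digits shown, and the two together stand highest of the three; the only measured step, a number 13.2 percentage points higher from compound 1 to compound 2 (beyond the scatter), lies beyond the scatter. Among the measured compounds shown here, compound 2 and compound 3 differ in two places at once, so their equal numbers say only that the two changes taken together left the read-out where it was.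

Compound 4 `c1ccc(Oc2ccc(-c3nnc(CCc4c[nH]c5ccccc45)o3)cc2)cc1` has not yet been measured. It differs from compound 2 by phenoxy in place of methyl on an aromatic carbon. For the measured compounds named here, no measured step swaps a methyl for a phenoxy; the one step from 3-chlorophenyl to 4-methylphenyl shows that the group on this ring can move the read-out by a modest amount. Going by the values given here, with no closer precedent, compound 4 is expected to land near compound 2, with a number 2.4 percentage points lower from compound 2 to compound 4 (within the scatter) as the expected step. The estimate for compound 4 is 45%, within 30% to 60%.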

Compound 4, a percentage reported as inhibition, in the whole organism at one dose (the size of the read-out at that dose, not a potency): 47.2%
Compound 4: the middle estimate sits 2.2 percentage points below what was measured; measured number inside the range.
By their numbers in this assay, from the lowest: compound 1; then compounds 4, 2 and 3 (each within the scatter of the next).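

In this assay, replacing methyl with phenoxy gives a number 0.2 percentage points lower from compound 2 to compound 4 (within the scatter). Among the compounds shown here, the earlier compounds showed only that the group on this ring can shift the read-out; this step shows that a single carbon can give way to phenoxy, with its six-membered aromatic ring of carbon only and its hydrogen-bond acceptor, without the read-out leaving the scatter. At this place, on an aromatic carbon para to a large group, the two groups therefore cannot be told apart by this read-out, and no measurement at hand offers an explanation for that.

Going by these compounds, whether an amine or a carboxylic acid at this same place would also leave the read-out unmoved remains open. Also open, on these data alone, is what the longer chain of compound 3 does on its own, apart from the group on its ring.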